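A few compounds are considered here, and "the series" means these few. Any claim that something is new, unique, unknown or untested is made for them only; others in the source may bear on it.

In a functional assay (Homo sapiens) for antiproliferative activity (a higher number here means a weaker inhibitor of growth, a lower number a stronger inhibitor of growth), compound 1 `Cc1cn2c(/C=N/NC(=N)N)c(-c3ccncc3)nc2s1` gives 28200 nM, compound 2 `Cc1cn2c(/C=N/NC(=N)N)c(-c3cccnc3)nc2s1` gives 51300 nM and compound 3 `N=C(N)N/N=C/c1c(-c2cc([N+](=O)[O-])c(Cl)cc2Cl)nc2sc(Cl)cn12` gives 44700 nM. Compound 1 thus lies within the scatter of both. Compound 4 `N=C(N)N/N=C/c1c(-c2ccncc2)nc2sc(Cl)cn12` awaits measurement and has chloro in place of methyl on an aromatic carbon, next to the ring sulfur: chloro in place of methyl on an aromatic carbon. Going by the values given here, the one measured step, a 1.8-fold higher number from compound 1 to compound 2 (0.26 log units; within the scatter), is a pyridin-3-yl for pyridin-4-yl change and does not touch that place. Among the compounds with values here, compound 3 also carries chloro there but differs in another group, so no measured step isolates this change. Its 44700 nM still gives no reason to expect a shift, and the expected step, a 1.1-fold higher number from compound 1 to compound 4 (0.03 log units; within the scatter), stays within the scatter. Compound 4 is estimated at 30000 nM, with an expected range of 14000 nM to 62000 nM.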

Compound 4, concentration for total growth inhibition: 11700 nM
Compound 4: middle estimate off by 2.6-fold (0.41 log units), on the high side; the measured number lies below the stated range.
By their numbers in this assay, from the lowest: compound 4; then compounds 1, 3 and 2 (each within the scatter of the next).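

Chloro in place of methyl on this aromatic carbon, next to the ring sulfur, gives a modest step beyond the scatter in this assay, a 2.4-fold lower number from compound 1 to compound 4 (0.38 log units; beyond the scatter). Going by these compounds alone, this position therefore responds to a single group exchange, whereas the only earlier step, at the pyridine, stayed within the scatter. Nothing measured here accounts for the change.

The compounds shown leave open whether a bromo, an amine or a methoxy group at this carbon would follow chloro or methyl. They also leave open whether chloro gives the same step with pyridin-3-yl in place of pyridin-4-yl.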